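Ring Nitrogen Swapped for Chloro on the Indazole Arm

This account rests on a few compounds, and the source may have more. Where it says the series, first, only, none or still open, it means among the compounds named here.

Compound 2 `O=C(Nc1ccc(-n2ncc3c(Cl)cccc32)cc1)Nc1ccc(Cl)c(C(F)(F)F)c1` is a urea that, in a functional assay on MDA-MB-231 cells (Homo sapiens) for cytotoxicity, read by MTT assay, with a stated time of 72 h (a higher number here means a weaker inhibitor, a lower number a stronger inhibitor), gives 1600 nM. Compound 1 `O=C(Nc1ccc(-n2ncc3c(C(F)(F)F)cccc32)cc1)Nc1ccc(Cl)c(C(F)(F)F)c1` gives 2000 nM and compound 3 `O=C(Nc1ccc(-n2ncc3c(Cl)cccc32)cc1)Nc1ccc(C(F)(F)F)cc1` gives 2700 nM, so all three numbers sit within the scatter of one another, and compound 2 cannot be separated from either neighbour. Among the measured compounds shown here, the only single-point step recorded, a 1.3-fold lower number from compound 1 to compound 2 (0.10 log units; within the scatter), lies within the scatter as well.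

Compound 4 `O=C(Nc1ccc(-n2ncc3cnccc32)cc1)Nc1ccc(Cl)c(C(F)(F)F)c1` has not been measured. It differs from compound 2 by a group of 9 heavy atoms (6 carbon, 3 nitrogen; one five-membered aromatic ring with 2 hetero atoms, one six-membered aromatic ring with 1 hetero atom) in place of a group of 10 heavy atoms (7 carbon, 2 nitrogen, 1 chlorine; one five-membered aromatic ring with 2 hetero atoms, one six-membered aromatic ring of carbon only), on an aromatic carbon. No measured step touches this part of the molecule, so nothing shown predicts the direction; a step of roughly a 1.9-fold higher number from compound 2 to compound 4 (0.27 log units; within the scatter) is expected, and for compound 4 a value of 3000 nM is estimated, with a range from 1000 nM to 9000 nM.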

Compound 4, half-maximal inhibitory concentration: 16000 nM
Compound 4: the middle estimate sits 5.3-fold (0.73 log units) below what was measured; measured number outside the range, above it.
By their numbers in this assay, from the lowest: compounds 2, 1 and 3 (each within the scatter of the next); then compound 4.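

In this assay, the swap of the 4-chloro-1H-indazol-1-yl group for its counterpart with a nitrogen in the six-membered ring gives a 10-fold higher number from compound 2 to compound 4 (1.00 log units; beyond the scatter), the only step shown that lies beyond the scatter. This arm therefore responds to some changes, whereas trading trifluoromethyl for chloro on it stayed within the scatter. Nothing available explains the step.

Going by these compounds, the step removes the chloro and adds the ring nitrogen together, so their separate shares remain open. Also open, on these data alone, is how a methyl group or an amine in place of the chloro would read.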